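Fluorine in Place of Hydroxyl on the Ring-Borne Chain

This account rests on a few compounds, and the source may have more. Where it says the series, first, only, none or still open, it means among the compounds named here.

Among the compounds with values here, compound 3, `C[C@H](O)[C@H]1C(=O)N2C(C(=O)O)=C(C(C)(C)C)O[C@H]12`, is one of three compounds so far measured in an ADME assay, in phosphate buffer, at 28 degrees C, at pH 7.0 (on this read-out higher numbers stand for a longer-lived compound and lower numbers for a shorter-lived compound), and in this assay compound 3 gives 7.1 h. Compound 1, `C[C@@H](O)[C@H]1C(=O)N2C(C(=O)O)=C(C(C)(C)C)O[C@H]12`, gives 8.1 h, and compound 2, `COC(=O)[C@@H](O)[C@H]1C(=O)N2C(C(=O)O)=C(C(C)(C)C)O[C@H]12`, gives 6.2 h; all three numbers sit within the scatter of one another, so no ordering among them can be claimed. Compounds 1 and 3 share every atom and bond, and the fact that compounds 1 and 3 differ only in the configuration as drawn is their only distinction, with a 1.1-fold lower number from compound 1 to compound 3 (0.06 log units; within the scatter). Compound 2 carries a methoxycarbonyl where compound 1 carries a methyl, with a 1.3-fold lower number from compound 1 to compound 2 (0.12 log units; within the scatter), and a 1.1-fold higher number from compound 2 to compound 3 (0.06 log units; within the scatter).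

Compound 4, `C[C@@H](F)[C@H]1C(=O)N2C(C(=O)O)=C(C(C)(C)C)O[C@H]12`, has not yet been measured. 1-fluoroethyl in place of 1-hydroxyethyl on a saturated ring carbon The three measured steps all alter the group on the same saturated ring carbon, and none of them moved the half-life beyond the scatter. The expected step is therefore also modest: a 1.0-fold lower number from compound 3 to compound 4 (0.01 log units; within the scatter). Compound 4 is estimated at 7 h, within a range from 3.5 h to 14 h.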

Compound 4, half-life: 3.5 h
Beside the measured number, compound 4's estimate is 2.0-fold (0.30 log units) above it; low and high end bracket the measured number.
By their numbers in this assay, from the lowest: compounds 4, 2, 3 and 1 (each within the scatter of the next, the first and the last beyond it).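

In this assay, within the data shown here, fluoro in place of hydroxy gives a 2.0-fold lower number from compound 3 to compound 4 (0.31 log units; beyond the scatter) and a 2.3-fold lower number from compound 1 to compound 4 (0.36 log units; beyond the scatter) on the chain at this saturated ring carbon, the first changes here to pass the scatter, which neither the change of drawn configuration nor the methoxycarbonyl change did. The shift appears from both drawn configurations of the 1-hydroxyethyl group, so it does not depend on which of the two is the starting point. The comparison with the hydroxy(methoxycarbonyl)methyl group goes against a general shift, since a 1.8-fold lower number from compound 2 to compound 4 (0.25 log units; within the scatter) stays within the scatter.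

Nothing measured here accounts for the shift. Open too, from the compounds shown here alone, is how an amine or a methoxy group on the same chain carbon would read, and how 1-fluoroethyl would read in the opposite drawn configuration.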